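Ethyl for tert-Butyl on a Sulfonamide Nitrogen

A few compounds are considered here, and "the series" means these few. Any claim that something is new, unique, unknown or untested is made for them only; others in the source may bear on it.

Compound 1 `CCN(CC)S(=O)(=O)c1ccc(S(=O)(=O)N2CCC[C@@H](C(=O)NC3CCN(C(=O)OC(C)(C)C)CC3)C2)cc1` gives 100 nM in a functional assay on MIA PaCa-2 cells (Homo sapiens) for inhibition, read by MTT assay, with a stated time of 7 days; a lower number here means a stronger inhibitor, a higher number a weaker inhibitor.
Compound 2 `CC(C)c1noc(N2CCN(C(=O)[C@@H]3CCCN(S(=O)(=O)c4ccc(S(=O)(=O)NC(C)(C)C)cc4)C3)CC2)n1` gives 300 nM in this assay.
Compound 3 `CCN(CC)S(=O)(=O)c1ccc(S(=O)(=O)N2CCC[C@@H](C(=O)N3CC4(CN(C(=O)OC(C)(C)C)C4)C3)C2)cc1` gives 400 nM in this assay.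

Of these three numbers, compound 2 holds the second highest. Its nearest neighbour is compound 3, whose number lies within the scatter of it; compound 1 sits furthest away, with a lower number that is beyond the scatter. Compound 4 `CCNS(=O)(=O)c1ccc(S(=O)(=O)N2CCC[C@@H](C(=O)N3CCN(c4nc(C(C)C)no4)CC3)C2)cc1` has not yet been measured. It differs from compound 2 in one place: ethyl in place of tert-butyl on a sulfonamide nitrogen. For the measured compounds named here, no measured pair shows this change on its own, so its effect in this assay is open. The author expects the step from compound 2 to compound 4 to be small, no change at the digits printed from compound 2 to compound 4 (within the scatter), in no clear direction beyond the scatter. For compound 4 the expected value in this assay is 300 nM, within a range from 100 nM to 1000 nM.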

Compound 4, half-maximal inhibitory concentration: 3300 nM
Compound 4: the middle estimate sits 11-fold (1.04 log units) below what was measured; the measured number lies above the stated range.
By their numbers in this assay, from the lowest: compound 1; then compounds 2 and 3 (each within the scatter of the next); then compound 4.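

In this assay, ethyl in place of tert-butyl on a sulfonamide nitrogen gives an 11-fold higher number from compound 2 to compound 4 (1.04 log units; beyond the scatter) and so a clearly weaker inhibitor. This single pair shows that this position is sensitive to the group it carries, even though the change removes only two carbons and no hydrogen-bond donors or acceptors. Nothing shown explains why the step is so large.

On these data alone, it remains open whether isopropyl or cyclopropyl on this nitrogen would keep the number of compound 2 or move towards that of compound 4. As far as these compounds go, whether this change has a similar effect on other cores also remains open.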